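Swapping the Aryl Group on a Ring Nitrogen

The source may hold more compounds than are shown below. What is called first, only, known or untested is meant among the compounds shown, and "the series" means these compounds.

Compound 1 `COc1cc2c(Oc3ccc(NC(=O)c4cn(-c5cc(C)ccc5C)cn4)cc3F)ccnc2cc1OCCCN1CCN(C)CC1`: in a functional assay on A549 cells (Homo sapiens) for cytotoxicity, read by MTT assay, with a stated time of 72 h (on this read-out higher numbers stand for weaker inhibition and lower numbers for stronger inhibition), compound 1 gives 350 nM.
Compound 2 `COc1cc2c(Oc3ccc(NC(=O)c4cn(-c5cc(C)ccc5C)cn4)cc3F)ccnc2cc1OCCCN1CCCCC1`: compound 2 gives 510 nM.
Compound 3 `COc1cc2c(Oc3ccc(NC(=O)c4cn(-c5ccccc5OC(F)(F)F)cn4)cc3F)ccnc2cc1OCCCN1CCC(C)CC1`: compound 3 gives 760 nM.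

Compound 3 has the highest of these three numbers; its gap to compound 2 lies within the scatter, its gap to compound 1 beyond it. Compound 4 `COc1cc2c(Oc3ccc(NC(=O)c4cn(-c5cc(C)ccc5C)cn4)cc3F)ccnc2cc1OCCCN1CCC(C)CC1` keeps the rest of compound 3 and carries 2,5-dimethylphenyl in place of 2-(trifluoromethoxy)phenyl on an aromatic nitrogen. Within the data shown here, the only single-site step measured, a 1.5-fold higher number from compound 1 to compound 2 (0.16 log units; within the scatter), alters the amine at the chain end, not the aryl group, so no measured step tests this change directly. Compounds 1 and 2 already carry the entering 2,5-dimethylphenyl group, and compound 2 and compound 3, which differ in two places, sit within the scatter of each other. A number close to compound 2 is therefore expected, with a 1.5-fold lower number from compound 3 to compound 4 (0.18 log units; within the scatter). Compound 4 is estimated at 500 nM, between 250 nM and 1000 nM.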

Compound 4, half-maximal inhibitory concentration: 7420 nM
Compound 4: middle estimate off by 15-fold (1.17 log units), on the low side; measured number above the stated range.
By their numbers in this assay, from the lowest: compounds 1, 2 and 3 (each within the scatter of the next, the first and the last beyond it); then compound 4.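

The aryl group on the ring nitrogen clearly matters: with 4-methylpiperidin-1-yl at the chain end, 2,5-dimethylphenyl in place of 2-(trifluoromethoxy)phenyl gives a 9.8-fold higher number from compound 3 to compound 4 (0.99 log units; beyond the scatter). The chain end also proves sensitive with 2,5-dimethylphenyl present, since one added methyl on the piperidine ring gives a 15-fold higher number from compound 2 to compound 4 (1.16 log units; beyond the scatter), and 4-methylpiperidin-1-yl in place of 4-methylpiperazin-1-yl gives a 21-fold higher number from compound 1 to compound 4 (1.33 log units; beyond the scatter). Nothing available explains these jumps. As far as these compounds go, whether the aryl change acts as strongly with other chain-end amines remains open. So does how a morpholin-4-yl chain end or a plain phenyl on the ring nitrogen would read.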